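Aryl in place of ethyl on the fused core

The compounds below may be only part of what the source reports. "The series", "measured", "known", "first", "only" and "open" are said of these compounds alone.

Compound 1 `CCc1nc2sccn2c1/C=N/OCc1ccc(Cl)c(Cl)c1` gives 2600 nM in an assay on HepG2 cells for agonist activity at nuclear receptor subfamily 1 group I member 3 (Homo sapiens), read by a luciferase reporter, with a stated time of 23 h; a lower number here means that less compound is needed, a higher number that more compound is needed for the effect. Among the three measured compounds it stands second highest: compound 3 `COc1ccc(CO/N=C/c2c(-c3ccc4ccccc4c3)nc3occn23)cc1` gives 4400 nM, within the scatter of compound 1, while compound 2 `Clc1ccc(CO/N=C/c2c(-c3ccc4ccccc4c3)nc3occn23)cc1Cl` gives 370 nM, a lower number beyond the scatter. Within the data shown here, the only step recorded between compounds differing in one place is a 12-fold higher number from compound 2 to compound 3 (1.08 log units; beyond the scatter); it concerns the group on the saturated chain carbon and does not touch the position changed here.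

Compound 4 `Clc1ccc(CO/N=C/c2c(-c3ccccc3)nc3sccn23)cc1Cl` differs from compound 1 by phenyl in place of ethyl on an aromatic carbon. Among the measured compounds shown here, no measured pair isolates this change. Compound 2 carries a larger aromatic group at the same position and shows a lower number than compound 1, but the two also differ in the fused ring, so the values cannot be split between the two differences. Because compound 2 with an aromatic group at this position gives 370 nM, compound 4 is expected to give 900 nM, with a range from 300 nM to 3000 nM. For the measured compounds named here, the expected step is a 2.9-fold lower number from compound 1 to compound 4 (0.46 log units; beyond the scatter), a moderate lowering in this assay, held with wide uncertainty since no measured step matches the change.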

Compound 4, half-maximal effective concentration: 580 nM
Compound 4: middle estimate off by 1.6-fold (0.19 log units), on the high side, and the stated range covers the measured number.
By their numbers in this assay, from the lowest: compounds 2 and 4 (each within the scatter of the next); then compounds 1 and 3 (each within the scatter of the next).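

Phenyl in place of ethyl on this aromatic carbon, next to the ring nitrogen, gives a 4.5-fold lower number from compound 1 to compound 4 (0.65 log units; beyond the scatter) in this assay and is the first measured step that isolates this position. Among these compounds, the fused ring and the 3,4-dichlorophenyl group stay the same across the pair, so the change in number belongs to this single replacement, whereas the one earlier step concerned only the group on the saturated chain carbon. The position on the core therefore responds to its substituent as well, though that reading rests on this one pair, and nothing measured gives a reason for the lowering.

As far as these compounds go, it remains open whether the lowering depends on the aromatic ring itself or on the larger group alone, which a cyclohexyl or a longer alkyl chain at the same carbon would help separate. Also open, from the compounds shown here alone, are how a pyridyl ring, an amine or a carboxylic acid would read at this position, and whether the same replacement gives a step of similar size when the fused ring of compound 2 is kept.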